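This account rests on a few compounds, and the source may have more. Where it says the series, first, only, none or still open, it means among the compounds named here.

Values in a toxicity assay on KB cells (Homo sapiens) for cytotoxicity, read by fluorescence, with a stated time of 3 days; a lower number here means that less compound is needed, a higher number that more compound is needed for the effect:
- Compound 1 `CCCCOC(=O)CNC(=O)[C@H](CSc1ccc([N+](=O)[O-])cc1[N+](=O)[O-])NC(=O)CC[C@H](NC(=O)CC(C)C)C(=O)OCCCC`: 59.6 uM
- Compound 2 `CCCCOC(=O)CNC(=O)[C@H](CSc1ccc([N+](=O)[O-])cc1[N+](=O)[O-])NC(=O)CC[C@H](NC(=O)CCc1c[nH]c2ccccc12)C(=O)OCCCC`: 26 uM
- Compound 3 `CCCCOC(=O)CNC(=O)[C@H](CSc1ccc([N+](=O)[O-])cc1[N+](=O)[O-])NC(=O)CC[C@H](NC(C)=O)C(=O)OCCCC`: > 300 uM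

Compound 3 stands at a limit of this assay, > 300 uM, and not at a number.

Compound 4 `CCCCOC(=O)CNC(=O)[C@H](CSc1ccc([N+](=O)[O-])cc1[N+](=O)[O-])NC(=O)CC[C@H](Nc1ccc([N+](=O)[O-])cc1[N+](=O)[O-])C(=O)OCCCC` carries the change (2,4-dinitrophenyl in place of acetyl on an amine nitrogen), which puts 2,4-dinitrophenyl in place of acetyl on an amine nitrogen. Within the data shown here, two measured steps bear on this end of the molecule: an at least 5.0-fold higher number from compound 1 to compound 3 (0.70 log units; beyond the scatter) and an at least 11-fold higher number from compound 2 to compound 3 (1.06 log units; beyond the scatter). Both end at the acetyl compound and rise, the second by a large amount. Read in reverse, they point to a lower number, though neither places an aromatic ring directly on the amine nitrogen. The expected step is an at least 8.5-fold lower number from compound 3 to compound 4 (0.93 log units; beyond the scatter), a large fall. The estimate for compound 4 is 35 uM, with an expected range of 10 uM to 130 uM.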

Compound 4, concentration for half-maximal effect: > 300 uM
Compound 4: no number, only a limit (the forecaster's own chance of this, stated with the estimate: 10%); at least 8.5-fold (0.93 log units) between middle value and limit.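

Compound 4 gives > 300 uM, a limit and not a number, so the rise seen with acetyl on this amine nitrogen is not undone by an aromatic ring placed directly on it. Putting 2,4-dinitrophenyl in place of isobutylcarbonyl gives an at least 5.0-fold higher number from compound 1 to compound 4 (0.70 log units; beyond the scatter). The step from acetyl to 2,4-dinitrophenyl cannot be read because compound 3 and compound 4 share one limit: the limit of > 300 uM in this assay, at which 2 of the 4 values shown sit.

Going by these compounds, whether a plain phenyl or benzyl group on this amine nitrogen would give a measurable number stays open. So does the effect of a longer chain on the amide carbonyl.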